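Alkoxy chain variation at the shared core: notes toward compound 4

The source may hold more compounds than are shown below. What is called first, only, known or untested is meant among the compounds shown, and "the series" means these compounds.

Measured compounds in a functional assay on mitochondria (Cricetulus griseus) for inhibition of Monoamine oxidase (Homo sapiens), tested at 0.3 uM; a higher number here means a stronger effect of the compound at the concentration tested, a lower number a weaker effect:
compound 1, `O=c1c(-c2ccc(O)cc2)coc2cc(OCCCBr)ccc12`, 51.1%
compound 2, `C=CCOc1ccc2c(=O)c(-c3ccc(O)cc3)coc2c1`, 37.9%
compound 3, `O=c1c(-c2ccc(O)cc2)coc2cc(OCC(O)CO)ccc12`, 33.3%

Compound 3 stands lowest of the three numbers. Its nearest neighbour is compound 2, and the step of a number 4.6 percentage points lower from compound 2 to compound 3 (within the scatter) lies within the scatter, so the two cannot be ordered. Within the data shown here, the step of a number 17.8 percentage points lower from compound 1 to compound 3 (beyond the scatter) lies beyond the scatter, as does a number 13.2 percentage points lower from compound 1 to compound 2 (beyond the scatter); compound 1 is the one compound that stands apart.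

The next compound, compound 4, `O=C(O)CCCCCCOc1ccc2c(=O)c(-c3ccc(O)cc3)coc2c1`, is not yet measured. It differs from compound 3 as follows:
5-carboxypentyl in place of 1,2-dihydroxyethyl on a saturated chain carbon bound to an oxygen on an aromatic ring

All three measured steps change only the group on the saturated chain carbon bound to the oxygen on the aromatic ring, so all three bear on this step. Two of them were modest and one was within the scatter; none gives a chain as long as the entering 5-carboxypentyl, and none carries a carboxylic acid. The exchange of one oxygen-bearing group for another at this position moved the number only within the scatter from compound 2 to compound 3, so the expectation for compound 4 is a step of a number 4.7 percentage points higher from compound 3 to compound 4 (within the scatter), upward if anything, but not firmly beyond the scatter. Compound 4 is therefore estimated at 38%, with a range from 20% to 56%.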

Compound 4, a percentage reported as inhibition, at one concentration (the size of the read-out at that concentration, not a potency): 48.6%
For compound 4 the middle estimate is 10.6 percentage points below the measured one, and the stated range covers the measured number.
By their numbers in this assay, from the lowest: compounds 3 and 2 (each within the scatter of the next); then compounds 4 and 1 (each within the scatter of the next).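

In this assay the 5-carboxypentyl group at this saturated chain carbon separates compound 4 from both the 1,2-dihydroxyethyl and the vinyl compounds, with modest steps of a number 15.3 percentage points higher from compound 3 to compound 4 (beyond the scatter) and a number 10.7 percentage points higher from compound 2 to compound 4 (beyond the scatter) in the two comparisons. Read from the other side, 3-carboxypropyl in place of bromo gives a number 2.5 percentage points lower from compound 1 to compound 4 (within the scatter) as a step, so the chain ending in a carboxylic acid and the bromopropyl chain cannot be ordered, and the four compounds now fall into two pairs, compounds 3 and 2 at the lower numbers and compounds 4 and 1 at the higher ones. Nothing measured here accounts for this grouping of the chains.

The compounds shown leave open how much of the step belongs to the length of the chain and how much to its carboxylic acid end, since a plain hexyl chain or a shorter chain ending in a carboxylic acid would be needed to separate the two. Also open, on these data alone, is whether an amine or a methyl ester at the end of the same chain would give a number like that of compound 4.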